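Thiazolyl in place of methoxyphenyl on the shared core

The source may report more compounds than this note shows. Statements on the series, on what has been measured and on what is new or still open speak of the compounds shown alone.

Compound 1 `O=C(NCCCCc1ccccc1)n1c(-c2ccccc2)coc1=O`, compound 2 `COc1ccc(-c2cn(C(=O)NCCCCc3ccccc3)c(=O)o2)cc1` and compound 3 `Cn1nc(-c2cn(C(=O)NCCCCc3ccccc3)c(=O)o2)c2ccccc21` share one core and differ only in the group attached to it. In an assay on isolated protein for inhibition of acid ceramidase (Homo sapiens), read by LC-MS, with a stated time of 1 h (a lower number here means a stronger inhibitor, a higher number a weaker inhibitor), compound 1 gives 70 nM, compound 3 gives 92 nM, and compound 2 gives 400 nM, the highest of the three numbers; its gaps to compound 3 and to compound 1 both lie beyond the scatter, so compound 2 is the weakest inhibitor of the set.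

Compound 4 `O=C(NCCCCc1ccccc1)n1cc(-c2cscn2)oc1=O` is not yet measured. Relative to compound 2 the change is 1,3-thiazol-4-yl in place of 4-methoxyphenyl on an aromatic carbon. Within the data shown here, no measured pair isolates this change; what is known is only that compound 1 sits far below compound 2 in this assay. A drop beyond the scatter is expected. Compound 4 is estimated at 150 nM, range 50 nM to 500 nM, with the expected step of a 2.7-fold lower number from compound 2 to compound 4 (0.43 log units; beyond the scatter).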

Compound 4, half-maximal inhibitory concentration: 44 nM
Compound 4: the middle estimate sits 3.4-fold (0.53 log units) above what was measured; the measured number lies below the stated range.
By their numbers in this assay, from the lowest: compounds 4, 1 and 3 (each within the scatter of the next, the first and the last beyond it); then compound 2.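

At the aromatic carbon next to the ring oxygen, 1,3-thiazol-4-yl in place of 4-methoxyphenyl gives a 9.1-fold lower number from compound 2 to compound 4 (0.96 log units; beyond the scatter) in this assay, so a six-membered aromatic ring of carbon only is not needed here for inhibition. Compound 3 and compound 4, which differ only in the group at this carbon, lie within the scatter of each other. Nothing at hand accounts for the step from compound 2. Open, as far as these compounds go, is whether the ring nitrogen, the sulfur or the missing methoxy group carries this step; a pyridin-3-yl or a 2-aminothiazol-4-yl at this carbon would bear on that.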